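The source may hold more compounds than are shown below. What is called first, only, known or untested is meant among the compounds shown, and "the series" means these compounds.

Among three compounds measured in an assay on isolated protein for inhibition of alpha-ketoglutarate-dependent dioxygenase alkB homolog 3 (Homo sapiens), read by polymerase chain reaction, with a stated time of 1 h (a higher number here means a weaker inhibitor, a lower number a stronger inhibitor), compound 2 `COc1ccc(Cc2c(C)[nH]n(-c3nc4ccccc4[nH]3)c2=O)cc1` gives 630 nM, the lowest number of the three, while compound 1 `Cc1[nH]n(-c2nc3cc(-c4ccccc4)ccc3[nH]2)c(=O)c1Cc1ccccc1` gives 810 nM and compound 3 `Cc1[nH]n(-c2nc3cc(Cl)ccc3[nH]2)c(=O)c1Cc1ccccc1` gives 4500 nM. Among the measured compounds shown here, the only single-point step measured, a 5.6-fold higher number from compound 1 to compound 3 (0.74 log units; beyond the scatter), concerns the core and not the benzyl group. For the measured compounds named here, compound 4 `Cc1[nH]n(-c2nc3ccccc3[nH]2)c(=O)c1Cc1cccc(Cl)c1` differs from compound 2 by 3-chlorophenyl in place of 4-methoxyphenyl on a saturated chain carbon bound to an aromatic carbon, a change at a place for which no measured step exists; compound 1 and compound 2 differ at two places, so their values show only that the two lie within the scatter. With nothing bearing on this change, compound 4 is expected to give 900 nM, between 300 nM and 3000 nM, an estimated step of a 1.4-fold higher number from compound 2 to compound 4 (0.15 log units; within the scatter) that is expected to stay within the scatter.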

Compound 4, half-maximal inhibitory concentration: 540 nM
Estimate against measurement, compound 4: 1.7-fold (0.22 log units) above; the range from low to high includes it.
By their numbers in this assay, from the lowest: compounds 4, 2 and 1 (each within the scatter of the next); then compound 3.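

In this assay, among the compounds shown here, 3-chlorophenyl in place of 4-methoxyphenyl on a saturated chain carbon bound to an aromatic carbon gives a 1.2-fold lower number from compound 2 to compound 4 (0.07 log units; within the scatter) and so provides the first measured step at this place. The exchange stays within the scatter even though the entering group has no hydrogen-bond acceptor and the leaving group has one. No evidence at hand offers an explanation for this result.

The compounds shown leave open how an amine, a carboxylic acid or a longer chain would read at this place. They also leave open whether other positions on this ring would give the same result.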